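A Longer Chain on the Ring Amine of Compound 1

The source may report more compounds than this note shows. Statements on the series, on what has been measured and on what is new or still open speak of the compounds shown alone.

compound 1 `CC(C)(C)OC(=O)CCCN1CCc2c(sc(NC(=O)Nc3ccc(Cl)cc3)c2C(N)=O)C1` — 560 nM
compound 2 `CCN1CCc2c(sc(NC(=O)Nc3ccc(Cl)cc3)c2C(=O)NC)C1` — > 25000 nM (a limit of the assay)
compound 3 `CCN1CCc2c(ccc(NC(=O)Nc3ccc(Cl)cc3)c2C(N)=O)C1` — > 25000 nM (a limit of the assay)

Going by the values given here, in a functional assay (strain AB) with Danio rerio as the target, read by microscopy, with a stated time of 1 h (on this read-out higher numbers stand for an effect only at larger amounts of compound and lower numbers for an effect already at smaller amounts), compound 1 gives 560 nM, the only actual number among the three measured compounds. For compound 2 this assay reports no number but only a limit, > 25000 nM. For compound 3 it likewise reports only a limit, > 25000 nM. Among the compounds with values here, what the measured set offers beside the value of compound 1 is therefore (the limit of > 25000 nM in this assay, at which 2 of the 3 values shown sit), and no pair of measured compounds differs in a single place, so no measured step gives a scale for any structural change.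

Compound 4 `CC(C)(C)OC(=O)CCCCN1CCc2c(sc(NC(=O)Nc3ccc(Cl)cc3)c2C(N)=O)C1` is the unmeasured compound. It differs from compound 1 by (tert-butoxycarbonyl)methyl in place of tert-butoxycarbonyl on a saturated chain carbon, three bonds along the chain from an amine nitrogen in a ring. Neither compound 2 nor compound 3 carries this chain, so the two limits say nothing about it. The step is expected to stay within the usual scatter, with no settled direction: a 1.1-fold higher number from compound 1 to compound 4 (0.03 log units; within the scatter). Compound 4 is accordingly estimated at about 600 nM in this assay, with a range from 200 nM to 2000 nM.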

Compound 4, half-maximal effective concentration: 710 nM
Compound 4: middle estimate off by 1.2-fold (0.07 log units), on the low side, and the stated range covers the measured number.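

In this assay, going by these compounds alone, setting (tert-butoxycarbonyl)methyl in place of tert-butoxycarbonyl on a saturated chain carbon, three bonds along the chain from an amine nitrogen in a ring, gives the first step in this set that can be read as a single change: a 1.3-fold higher number from compound 1 to compound 4 (0.10 log units; within the scatter). Within the data shown here, until now no two measured compounds differed in one place, so there was no scale for any change; this step shows that, at this place, compound 1 and compound 4 cannot be told apart in this assay, and that the longer chain keeps a measured number rather than a limit of the assay. Nothing in the data shown accounts for this outcome.

As far as these compounds go, this single step speaks only for this one lengthening of the chain with the tert-butyl ester kept at its end, so it remains open whether a still longer chain would read the same. From the compounds shown here alone, it also remains open how the compound would read with a carboxylic acid or an amine at the end of the chain in place of the ester.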